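The source may report more compounds than this note shows. Statements on the series, on what has been measured and on what is new or still open speak of the compounds shown alone.

Working notes on the series. Going by the values given here, of the two numbers so far in an assay for binding affinity to Alpha-1A adrenergic receptor (Homo sapiens) (a higher number here means a weaker inhibitor, a lower number a stronger inhibitor), compound 1 `O=c1c2ccccc2c(Cc2ccc(Cl)cc2)nn1CCNCCCCc1ccc(OCCCN2CCCCCC2)cc1` carries the larger, with compound 1 at 316 nM, though the gap to compound 2 lies within the scatter. Compound 2 `CN1CCC[C@@H]1Cn1nc(Cc2ccc(F)c(F)c2)c2ccccc2c1=O` gives 200 nM. Compound 3 `CN(CCCCc1ccc(OCCCN2CCCCCC2)cc1)CCn1nc(Cc2ccc(Cl)cc2)c2ccccc2c1=O` differs from compound 1 by methyl in place of hydrogen on an amine nitrogen. Among the compounds with values here, no measured pair carries this change, so no step size is known from the data; the expectation is a step of no more than the scatter, in either direction. Compound 3 is expected near 300 nM, with a range of 100 nM to 900 nM. The expected step is a 1.1-fold lower number from compound 1 to compound 3 (0.02 log units; within the scatter).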

Compound 3, inhibition constant: 1580 nM
Compound 3: middle estimate off by 5.3-fold (0.72 log units), on the low side; measured number above the stated range.
By their numbers in this assay, from the lowest: compounds 2 and 1 (each within the scatter of the next); then compound 3.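

In this assay, going by these compounds alone, methyl in place of hydrogen on an amine nitrogen gives a 5.0-fold higher number from compound 1 to compound 3 (0.70 log units; beyond the scatter) and is the first readable step. This nitrogen, whose other neighbours are two saturated chain carbons, is therefore sensitive to substitution, as one added carbon moves the number beyond the scatter. Nothing at hand bears on the reason for this rise. Going by these compounds, whether ethyl or a longer chain on this nitrogen would shift the number further remains open. The step is also known only on the background of compound 1, so its size on other backgrounds is open too.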